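A few compounds are considered here, and "the series" means these few. Any claim that something is new, unique, unknown or untested is made for them only; others in the source may bear on it.

Working notes on the series.

Of the compounds shown here, three have been measured in a physicochemical assay for lipophilicity, read by HPLC; on this read-out lower numbers stand for lower lipophilicity and higher numbers for higher lipophilicity. Compound 1 `Oc1ccc(/C=C/c2ccc3c(Cl)cc(Cl)c(O)c3n2)c(O)c1` gives 4.68 in this assay. Compound 2 `CCOc1ccccc1/C=C/c1ccc2c(Cl)cc(Cl)c(O)c2n1` gives 5.67 in this assay, which places compound 2 second highest of the three; its nearest neighbour is compound 1, whose number is lower by more than the scatter, and its furthest is compound 3 `Oc1c(Cl)cc(Cl)c2ccc(/C=C/c3ccc(/C=C/c4ccc5c(Cl)cc(Cl)c(O)c5n4)cc3)nc12`, which gives 8.88 in this assay, well beyond the scatter above compound 2. Within the data shown here, no two of the measured compounds differ in a single place, so no measured single step is available to lean on.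

Compound 4 `Oc1ccccc1/C=C/c1ccc2c(Cl)cc(Cl)c(O)c2n1` is not yet measured. Set against compound 2, the difference is hydrogen in place of ethyl on an oxygen on an aromatic ring. This removes the two-carbon ethyl group and leaves a hydroxy in place of the ethoxy. Such a change is expected to lower the number in this assay by an amount beyond the scatter, an expected step of a number 0.67 log units lower from compound 2 to compound 4 (beyond the scatter). Compound 4 is accordingly estimated at 5, expected to fall between 4.5 and 5.5 in this assay.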

Compound 4, partition coefficient: 5.07
Compound 4: the middle estimate sits 0.07 log units below what was measured; measured number inside the range.
By their numbers in this assay, from the lowest: compound 1; then compound 4; then compound 2; then compound 3.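

In this assay, the oxygen on the aromatic ring now has a measured single step: ethoxy to hydroxy gives a number 0.60 log units lower from compound 2 to compound 4 (beyond the scatter) and shows that the number responds to losing the ethyl group at this place. A second change runs the other way, since hydrogen in place of hydroxy on an aromatic carbon gives a number 0.39 log units higher from compound 1 to compound 4 (beyond the scatter) and so compound 4 stands with one step to each side. Nothing available accounts for the size or direction of either step.

Each change rests on a single pair, so neither step can yet be taken as general for the series. As far as these compounds go, how a longer chain such as propyl on this oxygen, or an amine or a carboxylic acid on the aromatic ring, would read remains open.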